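From Compound 2 to Compound 3: One Ring Exchanged

A few compounds are considered here, and "the series" means these few. Any claim that something is new, unique, unknown or untested is made for them only; others in the source may bear on it.

In a functional assay on A549 cells (Homo sapiens) for antiproliferative activity, read by MTT assay, with a stated time of 24 h (on this read-out lower numbers stand for stronger inhibition and higher numbers for weaker inhibition), compound 1 `CNC(=O)c1ccccc1Oc1nc(Nc2ccc(C(F)(F)F)cc2)ncc1Br` reads > 50000 nM, which is a limit of the assay and not a number. For the measured compounds named here, compound 2 `CNC(=O)c1ccccc1Oc1nc(Nc2ccccc2OC)ncc1Br` gives 40500 nM, the only actual number so far. Compound 3 `CNC(=O)c1ccccc1Oc1nc(Nc2ccc(Cl)cc2F)ncc1Br` keeps the shared core and changes one group: 4-chloro-2-fluorophenyl in place of 2-methoxyphenyl on a nitrogen on an aromatic ring, with 4-chloro-2-fluorophenyl in place of 2-methoxyphenyl on a nitrogen on an aromatic ring. Going by the values given here, no measured step is available as a guide. The expected step of a 1.2-fold lower number from compound 2 to compound 3 (0.06 log units; within the scatter) is no larger than the usual scatter, with no clear direction. For compound 3, the estimated value is 35000 nM, with an expected range from 12000 nM to 75000 nM.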

Compound 3, half-maximal inhibitory concentration: 38100 nM
Compound 3: the middle estimate sits 1.1-fold (0.04 log units) below what was measured, within the range that was stated.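

In this assay this position, on a nitrogen on an aromatic ring, now has its first readable step, a 1.1-fold lower number from compound 2 to compound 3 (0.03 log units; within the scatter) and so 4-chloro-2-fluorophenyl and 2-methoxyphenyl cannot be told apart here. Losing the oxygen and gaining fluorine and chlorine thus gives no measurable difference in this read-out. For the compounds shown here, compound 1 gives no step, since its value is a limit of the assay and not a number: the limit of > 50000 nM in this assay, at which 1 of the 3 values shown sits.

Still open, as far as these compounds go, is whether a group of another kind on this nitrogen, such as an aminoethyl chain or a carboxylic acid on the ring, would give a clearly lower number.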